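The source may hold more compounds than are shown below. What is called first, only, known or untested is meant among the compounds shown, and "the series" means these compounds.

In a functional assay on B16-F10 cells (Mus musculus) for inhibition, read by MTT assay, with a stated time of 48 h (on this read-out lower numbers stand for stronger inhibition and higher numbers for weaker inhibition), compound 1 `O=C(/C=C/c1ccc(Br)cc1)Nc1ccc2ncnc(Nc3cccc(Br)c3)c2c1` gives 10.7 ug/mL and compound 2 `O=C(/C=C/c1ccc(Br)cc1)Nc1ccc2ncnc(Nc3cccc(Cl)c3)c2c1` gives 0.75 ug/mL. Within the data shown here, of these two numbers compound 2 holds the lower one, and a 14-fold lower number from compound 1 to compound 2 (1.15 log units; beyond the scatter) is the only measured step: its change sits on the aryl group attached to the shared core through the amine. Compound 3 `COc1cccc(/C=C/C(=O)Nc2ccc3ncnc(Nc4cccc(Cl)c4)c3c2)c1` differs from compound 2 elsewhere: 3-methoxyphenyl in place of 4-bromophenyl on a double-bonded chain carbon bound to a double-bonded chain carbon. Among the measured compounds shown here, no measured pair separates compounds at this place, so no step on record bears on this change, and the size and direction of a 2.0-fold higher number from compound 2 to compound 3 (0.30 log units; within the scatter) can only be estimated loosely, with compound 2 as the anchor because of 0.75 ug/mL. Compound 3 is therefore expected to give a number in this assay close to that of compound 2, around 1.5 ug/mL, with a wide estimated range from 0.4 ug/mL to 6 ug/mL.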

Compound 3, half-maximal inhibitory concentration: 1.05 ug/mL
Compound 3: the middle estimate sits 1.4-fold (0.15 log units) above what was measured, within the range that was stated.
By their numbers in this assay, from the lowest: compounds 2 and 3 (each within the scatter of the next); then compound 1.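

In this assay, among these compounds, a 1.4-fold higher number from compound 2 to compound 3 (0.15 log units; within the scatter) is the first step read at this place, on a double-bonded chain carbon bound to a double-bonded chain carbon, and it shows that 3-methoxyphenyl can stand in place of 4-bromophenyl without a difference that can be told from the scatter. The swap is more than one small edit: bromine leaves, oxygen enters, a hydrogen-bond acceptor is gained and the ring numbering of the substituent shifts, and these parts are not separated here. Nothing on record gives a reason for this result. From the compounds shown here alone, whether an amine, a carboxylic acid or a longer chain on this ring would give a similar number remains open. So does whether chloro in place of bromo on the aryl group attached through the amine would matter as much alongside 3-methoxyphenyl.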